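The compounds below may be only part of what the source reports. "The series", "measured", "known", "first", "only" and "open" are said of these compounds alone.

The series shares a proline-thiazolidine core, measured in an assay on a cell-free system (plasma) for inhibition of Dipeptidyl peptidase 4 (Rattus norvegicus), read by fluorescence; on this read-out higher numbers stand for weaker inhibition and lower numbers for stronger inhibition. Compound 1 `N#Cc1ccc(C(=O)O[C@@H]2CN[C@H](C(=O)N3CCSC3)C2)cc1` carries an ester-linked benzonitrile; in this assay compound 1 gives only a limit, > 300 nM, the value being a limit rather than a number (the limit of > 300 nM in this assay, at which 1 of the 2 values shown sits). For the measured compounds named here, compound 2 `O=C([C@@H]1C[C@H](N2CCc3cc([N+](=O)[O-])ccc32)CN1)N1CCSC1` carries a nitro-substituted indoline amine on the core; in this assay compound 2 gives 10.3 nM, the only numerical value shown.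

Compound 3 `O=C([C@@H]1C[C@H](N2CCc3cc(Br)ccc32)CN1)N1CCSC1` is the halogen analogue of compound 2. The change is bromo in place of nitro on an aromatic carbon. Going by the values given here, no measured step of this kind exists, so nothing beyond the structural change itself supports an expectation. The expected step is a 1.5-fold higher number from compound 2 to compound 3 (0.16 log units; within the scatter), a change not beyond the usual scatter. In this assay compound 3 is estimated at 15 nM, with a range from 4 nM to 60 nM.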

Compound 3, half-maximal inhibitory concentration: 10.7 nM
Beside the measured number, compound 3's estimate is 1.4-fold (0.15 log units) above it; low and high end bracket the measured number.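

In this assay, bromo in place of nitro on the aromatic carbon gives a 1.0-fold higher number from compound 2 to compound 3 (0.02 log units; within the scatter), so this change does not separate the two compounds. At this position, a single bromine atom with no hydrogen-bond acceptors thus stands in for a nitro group of 3 heavy atoms and 2 hydrogen-bond acceptors, and in this pair a value of this order does not depend on those acceptors. No measured property at hand bears on this result.

On these data alone, whether an amino or a methoxy group on the same aromatic carbon would also stay within the scatter of compound 2 remains open. As far as these compounds go, compound 1 gives only a limit, > 300 nM, not a number, and it differs from compound 3 in more than one place, so the effect of the link between the core and the aromatic part also stays open.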